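Changing the Chain Group of Compound 1

The source may hold more compounds than are shown below. What is called first, only, known or untested is meant among the compounds shown, and "the series" means these compounds.

Compound 1 `N#CNC(=N)NCCCCCn1nc(-c2ccccc2)ccc1=O` is tested in a functional assay on the whole organism with Rattus norvegicus as the target, at a dose of 100 mg/kg (a lower number here means less inhibition, a higher number more inhibition at the dose given (going by the name of the read-out)), where compound 1 gives 31%. Two related compounds differ from it in one place each. Compound 2 `CC(C)(C)/N=C(\S)NCCCCn1nc(-c2ccccc2)ccc1=O` gives 33.6%, and compound 3 `CC/N=C(\S)NCCCn1nc(-c2ccccc2)ccc1=O` gives 39%. Among these three numbers compound 1 stands lowest, but the step of a number 2.6 percentage points higher from compound 1 to compound 2 (within the scatter) and the step of a number 8 percentage points higher from compound 1 to compound 3 (within the scatter) both lie within the scatter, so the three compounds cannot be told apart on this read-out.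

Compound 4 `CN(C)/C(=N/CCCCCCn1nc(-c2ccccc2)ccc1=O)NC#N` has not yet been measured. It differs from compound 1 as follows: a group of 9 heavy atoms (5 carbon, 4 nitrogen; no ring) in place of a group of 6 heavy atoms (2 carbon, 4 nitrogen; no ring), on a saturated chain carbon, five bonds along the chain from an aromatic nitrogen. The two measured steps bear on this change only loosely: each swapped one group for another on the saturated chain, and each left the read-out within the scatter. Going by the values given here, neither used a chain of the same length as compound 4, and no measured compound carries the entering group. On that basis the step of a number 2 percentage points higher from compound 1 to compound 4 (within the scatter) is expected to stay within the scatter, with no clear direction. Compound 4 is therefore estimated to give about 33% in this assay, with a range from 18% to 48%.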

Compound 4, a percentage reported as inhibition, in the whole organism at one dose (the size of the read-out at that dose, not a potency): 58.4%
Compound 4: the middle estimate sits 25.4 percentage points below what was measured; the whole stated range lies below it.
By their numbers in this assay, from the lowest: compounds 1, 2 and 3 (each within the scatter of the next); then compound 4.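

In this assay, the change on a saturated chain carbon, five bonds along the chain from an aromatic nitrogen, gives a number 27.4 percentage points higher from compound 1 to compound 4 (beyond the scatter), the only step shown that passes the scatter, so this read-out can respond to a swap of the chain group in a way the two earlier steps did not reveal. The swap alters several counts at once: the entering group has 9 heavy atoms against 6 and 1 hydrogen-bond donor against 3, while both groups have 4 nitrogen atoms, 1 double bond and 1 triple bond. No measurement at hand explains why the read-out differs between these two groups.

The compounds shown therefore cannot separate the effect of the added carbon atoms from that of the lost hydrogen-bond donors, and they leave open whether the step reflects the group itself or the chain that carries it. As far as these compounds go, it also remains open how a primary amine, a carboxylic acid or a longer chain would compare at this place on the shared core.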